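Removing a Fluoro Group and Expected Cell Toxicity

This account rests on a few compounds, and the source may have more. Where it says the series, first, only, none or still open, it means among the compounds named here.

Of the compounds shown here, three have been tested in an ADME assay on MT2 cells (Homo sapiens) for cytotoxicity, read by MTT assay; on this read-out higher numbers stand for lower toxicity in this test and lower numbers for higher toxicity in this test. Compound 1 `N#Cc1ccc2c(Oc3ccccc3OCCn3ccc(=O)[nH]c3=O)cc(F)cc2c1` reaches only the limit of the assay, > 100000 nM, not a number. Compound 2 `N#Cc1ccc2c(Oc3ccc(F)cc3OCCn3ccc(=O)[nH]c3=O)cc(F)cc2c1` likewise gives only a limit, > 100000 nM. Compound 3 `N#Cc1cc2c(Oc3ccc(F)cc3OCCn3ccc(=O)[nH]c3=O)cc(Cl)cn2c1` gives a real number in this assay, 15000 nM; how its core differs from the core of compound 2 is not broken down here. Compound 2 turns into compound 1 by hydrogen in place of fluoro on an aromatic carbon, a step that the two limits leave unreadable from compound 2 to compound 1; its size cannot be read because the limit of > 100000 nM in this assay, at which 2 of the 3 values shown sit, applies to both members of that pair. Compound 4 `N#Cc1cc2c(Oc3ccccc3OCCn3ccc(=O)[nH]c3=O)cc(Cl)cn2c1` is not yet measured and arises from compound 3 by the same change, (hydrogen in place of fluoro on an aromatic carbon). With the earlier example of this change unreadable, the expectation rests on compound 3 and its value 15000 nM alone. In this assay compound 4 is therefore expected to give 20000 nM. The expected step of a 1.3-fold higher number from compound 3 to compound 4 (0.12 log units; within the scatter) is small.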

Compound 4, half-maximal cytotoxic concentration: 39000 nM
Compound 4: middle estimate off by 2.0-fold (0.29 log units), on the low side; the range from low to high includes it.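

In this assay, hydrogen in place of fluoro gives a 2.6-fold higher number from compound 3 to compound 4 (0.41 log units; beyond the scatter), a modest step towards lower toxicity in this test. Among these compounds, this shows that the change can matter on the core of compound 3, but that core provides the only readable example. The same change on the core of compound 2 cannot be read, so it cannot be said whether the step carries over from one core to the other, because both members of that pair give only a limit: the limit of > 100000 nM in this assay, at which 2 of the 4 values shown sit.

The compounds shown leave open how a methyl group or an amine in place of the fluoro group would read in this assay. They also leave open whether the step would hold on a third core.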